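The compounds below may be only part of what the source reports. "The series", "measured", "known", "first", "only" and "open" are said of these compounds alone.

The measured compounds:

compound 1, `C#CCN(C)Cc1cn(-c2cc(NC(=S)NCC)ncn2)cn1` — 20.2%
compound 2, `C#CCN(CC)Cc1cn(-c2cc(NC(=S)NCC)ncn2)cn1` — 6.71%

Of the compounds shown here, two have been measured in an assay on isolated protein for inhibition of Amine oxidase [flavin-containing] A (Homo sapiens), read by fluorescence and Amplex Red, with a stated time of 15 min, tested at 50 uM (on this read-out higher numbers stand for more inhibition at the one concentration tested (going by the name of the read-out) and lower numbers for less inhibition), and they share a core with an ethynyl-bearing amine nitrogen whose second substituent differs. Compound 1 gives 20.2% in this assay, and compound 2 gives 6.71%. Going by the values given here, compound 2 therefore stands at the lower of the two numbers; the one step that separates them, a number 13.5 percentage points lower from compound 1 to compound 2 (beyond the scatter), is a modest drop beyond the scatter, brought about by methyl in place of hydrogen on a saturated chain carbon bound to an amine nitrogen.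

Compound 3, `C#CCN(CCC)Cc1cn(-c2cc(NC(=S)NCC)ncn2)cn1`, extends the same chain by one more carbon. The difference from compound 2 is methyl in place of hydrogen on a saturated chain carbon, two bonds along the chain from an amine nitrogen. Among the compounds with values here, only the step of a number 13.5 percentage points lower from compound 1 to compound 2 (beyond the scatter) bears on this change, and it is the same kind of difference cut one bond further out. Because the step of a number 13.5 percentage points lower from compound 1 to compound 2 (beyond the scatter) was modest and compound 2 already sits low at 6.71%, the expectation for compound 3 is a small drop or nothing beyond the scatter, a number 3.7 percentage points lower from compound 2 to compound 3 (within the scatter). Compound 3 is expected to give 3%, estimated between -6% and 14%.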

Compound 3, a percentage reported as inhibition, at one concentration (the size of the read-out at that concentration, not a potency): 1.76%
Compound 3: the middle estimate sits 1.2 percentage points above what was measured, and the stated range covers the measured number.
By their numbers in this assay, from the lowest: compounds 3 and 2 (each within the scatter of the next); then compound 1.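

Lengthening the substituent on the amine nitrogen from ethyl to propyl gives a number 5 percentage points lower from compound 2 to compound 3 (within the scatter) in this assay, so this change cannot be told apart from no change, whereas methyl to ethyl had given a number 13.5 percentage points lower from compound 1 to compound 2 (beyond the scatter). Over the whole change from methyl to propyl, the printed step is a number 18.4 percentage points lower from compound 1 to compound 3 (beyond the scatter), so the gap from compound 1 that opened with ethyl also holds with propyl, and among these three compounds only the methyl compound stands apart from the other two. Nothing in the data explains this behaviour of the chain at this position.

As far as these compounds go, whether a hydrogen in place of the methyl on the amine nitrogen, or a branched group such as isopropyl or a ring such as cyclopropyl, would give a number different from that of compound 1 at 20.2% remains open. A longer chain such as butyl is open too, although the read-out at one concentration gives no potency, and numbers this low leave little room to separate further chain lengths.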